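This account rests on a few compounds, and the source may have more. Where it says the series, first, only, none or still open, it means among the compounds named here.

Working notes on the series, measured in a functional assay on CWR22R cells (Homo sapiens) for inhibition, read by MTT assay; a higher number here means a weaker inhibitor of growth, a lower number a stronger inhibitor of growth:

- compound 1 `CC1=C(/C=C/C(C)=C/C=C/C(C)=C\C(=O)Nc2ccccc2)C(C)(C)CCC1n1ccnc1`: 1280 nM
- compound 2 `CC1=C(/C=C/C(C)=C/C=C/C(C)=C\C(=O)Nc2ccc(F)cc2)C(C)(C)CCC1n1ccnc1`: 8120 nM
- compound 3 `CC1=C(/C=C/C(C)=C/C=C/C(C)=C\C(=O)NCc2ccccc2)C(C)(C)CCC1n1ccnc1`: > 100000 nM, a limit of the assay and not a number

Going by these compounds, compound 3 has only this limit, as the limit of > 100000 nM in this assay, at which 1 of the 3 values shown sits, records, so its true position on the scale is unknown. The next compound is compound 4 `CC1=C(/C=C/C(C)=C/C=C/C(C)=C\C(=O)Nc2ccccc2O)C(C)(C)CCC1n1ccnc1`. The change is 2-hydroxyphenyl in place of benzyl on an amide-type nitrogen.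

Within the data shown here, two measured steps bear on this change, both read in reverse, since they go from an aryl amide to the benzyl amide. They are an at least 78-fold higher number from compound 1 to compound 3 (1.89 log units; beyond the scatter) and an at least 12-fold higher number from compound 2 to compound 3 (1.09 log units; beyond the scatter). Both are large, and both end at the limit, so each gives only a minimum size. Compound 4 keeps a ring directly on the amide nitrogen, as compound 1 and compound 2 do, so a large step to a lower number is expected. A third step tempers the expectation: a 6.3-fold higher number from compound 1 to compound 2 (0.80 log units; beyond the scatter) shows that a substituent on the phenyl ring can cost strength, although that substituent is fluoro and not hydroxy. Among the measured compounds shown here, no measured compound carries the 2-hydroxyphenyl group.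

The expected change is an at least 25-fold lower number from compound 3 to compound 4 (1.39 log units; beyond the scatter). For compound 4 the estimated value is 4000 nM, with an expected range of 600 nM to 30000 nM.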

Compound 4, concentration for 50% growth inhibition: 2230 nM
Beside the measured number, compound 4's estimate is 1.8-fold (0.25 log units) above it; measured number inside the range.
By their numbers in this assay, from the lowest: compounds 1 and 4 (each within the scatter of the next); then compound 2. At a limit, above all of these: compound 3.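

In this assay, hydroxy in place of hydrogen on the phenyl ring gives a 1.7-fold higher number from compound 1 to compound 4 (0.24 log units; within the scatter), so this substituent leaves compound 4 within the scatter of compound 1, whereas the fluoro of compound 2 moved the number beyond it. The direct comparison of the two substituted rings gives a 3.6-fold lower number from compound 2 to compound 4 (0.56 log units; beyond the scatter), which shows that the cost seen with 4-fluorophenyl does not extend to every substituted phenyl on the amide nitrogen, at least not to 2-hydroxyphenyl. Compound 3 remains a limit of the assay and not a number, so an at least 44-fold lower number from compound 3 to compound 4 (1.65 log units; beyond the scatter) gives only a minimum size for the change from benzyl to 2-hydroxyphenyl: the limit of > 100000 nM in this assay, at which 1 of the 4 values shown sits.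

The compounds shown do not tell whether the hydroxy group itself matters on the ring or whether another group in its place, such as a methoxy or an amine, would sit equally close to compound 1. They also leave open how a longer chain between the amide nitrogen and the phenyl ring would read, since the benzyl amide compound 3 offers only a limit for comparison.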